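The source may hold more compounds than are shown below. What is called first, only, known or untested is meant among the compounds shown, and "the series" means these compounds.

Measured compounds:
Compound 1, `Cc1nnc(SCC(=O)N/N=c2/scc(-c3ccc(F)cc3)n2-c2ccccc2)s1`: 73.7%
Compound 2, `COc1ccc(-c2cs/c(=N/NC(=O)CSc3nnc(C)s3)n2-c2ccccc2)cc1`: 53.6%
Compound 3, `COc1ccc(-c2cs/c(=N/NC(=O)CSc3ncccn3)n2-c2ccccc2)cc1`: 78.4%

Three compounds have been run in a functional assay on C6 cells (Rattus norvegicus) for cytotoxicity, read by MTT assay, with a stated time of 24 h, tested at 12 ug/mL; a higher number here means a weaker effect of the compound at the concentration tested, a lower number a stronger effect. Compound 2 gives 53.6%, the lowest of the three numbers. Compound 1 differs from compound 2 by fluoro in place of methoxy on an aromatic carbon, and this change produced a number 20.1 percentage points higher from compound 2 to compound 1 (beyond the scatter). Compound 3 differs from compound 2 by pyrimidin-2-yl in place of 5-methyl-1,3,4-thiadiazol-2-yl on a sulfur, which produced a number 24.8 percentage points higher from compound 2 to compound 3 (beyond the scatter). The numbers of compound 1 and compound 3 lie within the usual scatter of each other, so no order can be read between them.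

Compound 4, `O=C(CSc1ncccn1)N/N=c1/scc(-c2ccc(F)cc2)n1-c1ccccc1`, has not yet been measured in this assay. It differs from compound 3 by fluoro in place of methoxy on an aromatic carbon. This is the same change that was made from compound 2 to compound 1, where it gave a number 20.1 percentage points higher from compound 2 to compound 1 (beyond the scatter); the place of the change is described in the same words for both pairs. The two cores on which the change is made differ by pyrimidin-2-yl in place of 5-methyl-1,3,4-thiadiazol-2-yl on a sulfur.

On the strength of that earlier step, compound 4 is expected to sit higher than compound 3, by an estimated a number 9.6 percentage points higher from compound 3 to compound 4 (within the scatter). For the measured compounds named here, the step is expected to be somewhat smaller than the one from compound 2 to compound 1 because the number of compound 3, 78.4%, already lies close to the top of the scale. Compound 4 is therefore estimated at 88%, with a likely range from 72% to 100%.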

Compound 4, a percentage reported as activity, at one concentration (the size of the read-out at that concentration, not a potency): 77.4%
Compound 4: the middle estimate sits 10.6 percentage points above what was measured; the measured number falls inside the stated range.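

In this assay, fluoro in place of methoxy on the core carrying the pyrimidin-2-yl group gives a number 1 percentage points lower from compound 3 to compound 4 (within the scatter), so the step seen on the core carrying the 5-methyl-1,3,4-thiadiazol-2-yl group did not carry over to this second core: the same change on two cores in this assay, a number 20.1 percentage points higher (beyond the scatter) from compound 2 to compound 1 and a number 1 percentage points lower (within the scatter) from compound 3 to compound 4, 21.1 percentage points apart, beyond the scatter of two such steps. Read the other way, pyrimidin-2-yl in place of 5-methyl-1,3,4-thiadiazol-2-yl gives a number 3.7 percentage points higher from compound 1 to compound 4 (within the scatter) on the fluoro core, and this step too differs from its counterpart on the methoxy core: the same change on two cores in this assay, a number 24.8 percentage points higher (beyond the scatter) from compound 2 to compound 3 and a number 3.7 percentage points higher (within the scatter) from compound 1 to compound 4, 21.1 percentage points apart, beyond the scatter of two such steps. Across these four compounds, therefore, neither change can be carried from one core to another as a fixed amount, although this rests on a single pair of steps for each change and does not show why the steps differ or how other groups would behave.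

The compounds shown leave open whether a chloro or a hydroxy group in the place of the fluoro or methoxy group would also depend on the group on the sulfur. They also leave open whether a pyridin-2-yl group on the sulfur would behave like the pyrimidin-2-yl or the 5-methyl-1,3,4-thiadiazol-2-yl group.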